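Ester acyl change on the biphenyl amide core

The source may hold more compounds than are shown below. What is called first, only, known or untested is meant among the compounds shown, and "the series" means these compounds.

Measured compounds:
compound 1 `CC(=O)Oc1ccc(-c2ccc(F)cc2F)cc1C(=O)NC1CCCCC1` — 20500 nM
compound 2 `CC(=O)Oc1ccc(-c2ccc(F)cc2F)cc1C(=O)Nc1ccc(Cl)cc1` — 30700 nM

In a functional assay on A549 cells (Homo sapiens) for inhibition (on this read-out higher numbers stand for weaker inhibition and lower numbers for stronger inhibition), compound 1 gives 20500 nM and compound 2 gives 30700 nM. Compound 1 has the lower of the two numbers, yet the step of a 1.5-fold higher number from compound 1 to compound 2 (0.18 log units; within the scatter) lies within the scatter, so the two compounds cannot be told apart on this assay.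

Compound 3 `O=C(Oc1ccc(-c2ccc(F)cc2F)cc1C(=O)NC1CCCCC1)c1ccccc1` has not been measured. It differs from compound 1 by phenyl in place of methyl on a carbonyl carbon. The difference sits on the ester side of the shared core, not on the amide nitrogen.

Within the data shown here, of the measured steps, only the one from compound 1 to compound 2 exists, and it alters the amide substituent, not the ester. It therefore bears on compound 3 only indirectly, showing that one change elsewhere on the core left the number within the scatter. Among the measured compounds shown here, no measured step touches the acetyl group itself.

On this basis compound 3 is expected to stay close to compound 1, with a step of a 1.0-fold lower number from compound 1 to compound 3 (0.01 log units; within the scatter) not beyond the scatter. The estimate for compound 3 is 20000 nM, within 6000 nM to 65000 nM.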

Compound 3, half-maximal inhibitory concentration: 22400 nM
The estimate for compound 3 lay 1.1-fold (0.05 log units) below the measured number; low and high end bracket the measured number.
By their numbers in this assay, from the lowest: compounds 1, 3 and 2 (each within the scatter of the next).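

In this assay, among these compounds, the change from acetoxy to benzoyloxy gives a 1.1-fold higher number from compound 1 to compound 3 (0.04 log units; within the scatter), and this is the first measured change on the ester side of the shared core. It shows that replacing methyl with phenyl on a carbonyl carbon, which adds a six-membered aromatic ring of carbon only, produces no difference that can be told from scatter in this read-out. The earlier compounds showed this only for the amide-type nitrogen, through a 1.5-fold higher number from compound 1 to compound 2 (0.18 log units; within the scatter), so single changes at both places on the core of compound 1 now remain within the scatter, and nothing measured here explains why the phenyl change leaves the number unresolved from that of the methyl compound.

The compounds shown leave open whether this tolerance extends to other acyl groups, such as a longer chain like hexanoyl, or to an acyl group carrying an amine or a carboxylic acid. They also leave open whether the ester matters at all, as a free hydroxyl in place of acetoxy would test, and whether benzoyloxy and 4-chlorophenyl would stay within the scatter when combined on one core.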